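Bromo to nitrooxy on the amide side chain

The source may report more compounds than this note shows. Statements on the series, on what has been measured and on what is new or still open speak of the compounds shown alone.

Three analogues share one core. Compound 1 `Nc1ccc(C(=O)/C=C/c2ccc(Cl)cc2)cc1` gives 58% in a functional assay on the whole organism (strain albino) for inhibition, with Rattus norvegicus as the target, read by paw edema, with stated times of 30 min and 4 h, at a dose of 100 mg/kg by the oral route; on this read-out higher numbers stand for more inhibition at the one dose given (going by the name of the read-out) and lower numbers for less inhibition. Compound 2 `O=C(CBr)Nc1ccc(C(=O)/C=C/c2ccc(Cl)cc2)cc1` gives 59% in this assay, a change of a number 1 percentage points higher from compound 1 to compound 2 (within the scatter). Compound 3 `CC(Br)C(=O)Nc1ccc(C(=O)/C=C/c2ccc(Cl)cc2)cc1` gives 54% in this assay; the step is a number 4 percentage points lower from compound 1 to compound 3 (within the scatter), and against compound 2 it is a number 5 percentage points lower from compound 2 to compound 3 (within the scatter). Compound 3 therefore sits apart from both neighbours only by amounts inside the scatter, so none of the three can be told from the others.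

Compound 4 `CC(O[N+](=O)[O-])C(=O)Nc1ccc(C(=O)/C=C/c2ccc(Cl)cc2)cc1` follows from compound 3 by nitrooxy in place of bromo on a saturated chain carbon bound to a carbonyl carbon and a saturated chain carbon. Going by the values given here, no measured step exchanges bromo for nitrooxy, so the only guidance comes from the steps on this same side chain, a number 1 percentage points higher from compound 1 to compound 2 (within the scatter), a number 4 percentage points lower from compound 1 to compound 3 (within the scatter) and a number 5 percentage points lower from compound 2 to compound 3 (within the scatter), each inside the scatter. Compound 4 is therefore expected to change by a number 1 percentage points higher from compound 3 to compound 4 (within the scatter), that is, by nothing beyond the scatter. Compound 4 is estimated at 55%, between 44% and 66%.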

Compound 4, a percentage reported as inhibition, in the whole organism at one dose (the size of the read-out at that dose, not a potency): 61%
Beside the measured number, compound 4's estimate is 6 percentage points below it; the measured number falls inside the stated range.
By their numbers in this assay, from the lowest: compounds 3, 1, 2 and 4 (each within the scatter of the next).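

In this assay, nitrooxy in place of bromo on a saturated chain carbon bound to a carbonyl carbon and a saturated chain carbon gives a number 7 percentage points higher from compound 3 to compound 4 (within the scatter) and so, at this position, four heavy atoms with three hydrogen-bond acceptors can stand where one bromine stood without a difference that can be told from the scatter. The other two comparisons read the same way, with a number 2 percentage points higher from compound 2 to compound 4 (within the scatter) and a number 3 percentage points higher from compound 1 to compound 4 (within the scatter) leaving the 1-(nitrooxy)ethyl side chain indistinguishable from the bromomethyl side chain and from the hydrogen on the nitrogen. No evidence bears on this result.

As far as these compounds go, whether an amine, a hydroxyl or a carboxylic acid on this carbon, or a longer chain in place of its methyl, would move the number beyond the scatter stays open. Also open, from the compounds shown here alone, is how nitrooxy would read on the side chain without that methyl.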